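A few compounds are considered here, and "the series" means these few. Any claim that something is new, unique, unknown or untested is made for them only; others in the source may bear on it.

Compound 2 `Cc1ccc(NC2=C(C(=O)c3ccccc3)C(c3ccc(Br)cc3)N(CCCn3ccnc3)C2=O)cc1` belongs to a set of three measured analogues sharing one core, the others being compound 1 `O=C(C1=C(OC2CCCCC2)C(=O)N(CCCn2ccnc2)C1c1ccc(Br)cc1)c1ccccc1` and compound 3 `O=C(C1=C(Nc2ccccc2Br)C(=O)N(CCCn2ccnc2)C1c1ccc(Br)cc1)c1ccccc1`. In a functional assay on A549 cells (Homo sapiens) for antiproliferative activity, read by MTT assay, with a stated time of 72 h (a higher number here means a weaker inhibitor, a lower number a stronger inhibitor), compound 2 gives 29400 nM, the second highest of the three numbers. Compound 1 gives 31200 nM in this assay, and compound 3 gives 20100 nM. Going by the values given here, the steps among them are all small: a 1.1-fold lower number from compound 1 to compound 2 (0.03 log units; within the scatter), a 1.6-fold lower number from compound 1 to compound 3 (0.19 log units; within the scatter) and a 1.5-fold lower number from compound 2 to compound 3 (0.17 log units; within the scatter), each within the scatter, so no compound of the three can be called stronger or weaker than another.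

Compound 4 `O=C(C1=C(NCc2ccccc2)C(=O)N(CCCn2ccnc2)C1c1ccc(Br)cc1)c1ccccc1` differs from compound 2 in one place: benzyl in place of 4-methylphenyl on an amine nitrogen. The step that bears most directly on this change also swaps the group on the amine nitrogen: a 1.5-fold lower number from compound 2 to compound 3 (0.17 log units; within the scatter). The two steps in which (4-methylphenyl)amino or (2-bromophenyl)amino replaces cyclohexyloxy, a 1.1-fold lower number from compound 1 to compound 2 (0.03 log units; within the scatter) and a 1.6-fold lower number from compound 1 to compound 3 (0.19 log units; within the scatter), likewise stay within the scatter. Nothing among these three compounds suggests that the benzylamino variant should move out of the range they occupy, so the expected step in this assay is a 1.1-fold lower number from compound 2 to compound 4 (0.05 log units; within the scatter), not beyond the scatter in either direction. Compound 4 is therefore estimated at 26000 nM in this assay, with a range from 11000 nM to 60000 nM.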

Compound 4, half-maximal inhibitory concentration: 52800 nM
The estimate for compound 4 lay 2.0-fold (0.31 log units) below the measured number; measured number inside the range.
By their numbers in this assay, from the lowest: compounds 3, 2, 1 and 4 (each within the scatter of the next, the first and the last beyond it).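

In this assay, going by these compounds alone, benzyl in place of 2-bromophenyl on the amine nitrogen gives a 2.6-fold higher number from compound 3 to compound 4 (0.42 log units; beyond the scatter) and is the first step to pass the scatter, which shows that the group at this position can separate two compounds, if only modestly. Benzyl in place of 4-methylphenyl, a swap with the same heavy atoms on both sides, gives a 1.8-fold higher number from compound 2 to compound 4 (0.25 log units; within the scatter) and benzylamino in place of cyclohexyloxy gives a 1.7-fold higher number from compound 1 to compound 4 (0.23 log units; within the scatter), so compound 4 cannot be told apart from compound 2 or compound 1. Nothing shown here offers an explanation for the one pair that does separate.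

The compounds shown leave open whether that separation depends on the bromine of compound 3, which plain phenyl or 2-chlorophenyl on the same nitrogen could test. They also leave open how this assay would read with a group of a different kind on that nitrogen, such as a chain ending in a dimethylamine or a carboxylic acid.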